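The source may report more compounds than this note shows. Statements on the series, on what has been measured and on what is new or still open speak of the compounds shown alone.

Measured in a functional assay for inhibition, using microsomes, tested at 100 ug/mL; on this read-out lower numbers stand for a stronger effect and higher numbers for a weaker effect at the one concentration tested:
compound 1 `CCOC(=O)C1=C(C)N(c2ccccc2)C=CC1c1ccccc1`: -19.9%
compound 2 `CCOC(=O)C1=C(C)N(c2ccc(F)cc2)C=CC1c1ccccc1`: -28.5%

Compound 2 gives the lowest of the two numbers in this assay, but its nearest neighbour is compound 1, and the step of a number 8.6 percentage points lower from compound 1 to compound 2 (within the scatter) stays within the scatter, so the two compounds cannot be ordered on this read-out.

Compound 3 `CCOC(=O)C1=C(C)N(c2ccc(Cl)cc2)C=CC1c1ccccc1` is not yet measured. Its difference from compound 2 is chloro in place of fluoro on an aromatic carbon. Among the measured compounds shown here, no measured step exchanges one halogen for another; the only step available, a number 8.6 percentage points lower from compound 1 to compound 2 (within the scatter), touches the same position and was within the scatter. On that basis no step beyond the scatter is expected from compound 2 to compound 3 in this assay, and the expected step is a number 1.5 percentage points lower from compound 2 to compound 3 (within the scatter).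

The value of compound 3 in this assay is estimated at -30%, with a range from -50% to -10%.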

Compound 3, a percentage reported as activity, at one concentration (the size of the read-out at that concentration, not a potency): -25.5%
For compound 3 the middle estimate is 4.5 percentage points below the measured one, and the stated range covers the measured number.
By their numbers in this assay, from the lowest: compounds 2, 3 and 1 (each within the scatter of the next).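

The 4-fluorophenyl to 4-chlorophenyl exchange on an aromatic carbon para to a large group gives, in this assay, a number 3 percentage points higher from compound 2 to compound 3 (within the scatter), so this first direct comparison of two halogens at the position does not tell chloro from fluoro. Chloro in place of hydrogen gives a number 5.6 percentage points lower from compound 1 to compound 3 (within the scatter), which means that, like fluoro, chloro does not separate from hydrogen here on this read-out. No supporting data bear on these results.

Open, on these data alone, is whether a group of another kind at this position, such as an amine or a methoxy group, would give a step beyond the scatter. Also open, as far as these compounds go, is whether a change elsewhere on the shared core, such as a carboxylic acid in place of the ethyl ester, would do so.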